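The compounds below may be only part of what the source reports. "The series", "measured", "known", "first", "only" and "open" are said of these compounds alone.

Measured compounds:
- compound 1 `Cc1cc(C)cc(S(=O)(=O)c2c(C(=O)NC(C)C(=O)NC(C)c3ccncc3)[nH]c3ccc(Cl)cc23)c1`: 21900 nM
- compound 2 `Cc1cc(C)cc(S(=O)(=O)c2c(C(=O)NCc3ccc4nc(N)[nH]c4c3)[nH]c3ccc(Cl)cc23)c1`: 5890 nM
- compound 3 `Cc1cc(C)cc(S(=O)(=O)c2c(C(=O)NC(C)C(=O)NCc3ccncn3)[nH]c3ccc(Cl)cc23)c1`: 28100 nM

All three values come from an ADME assay on MT4 cells (Homo sapiens) for cytotoxicity, read by MTT assay; a higher number here means that more compound is tolerated, a lower number that less compound is tolerated. Compound 3 gives the highest number of the three; one step is a 1.3-fold higher number from compound 1 to compound 3 (0.11 log units; within the scatter), and the other is a 4.8-fold higher number from compound 2 to compound 3 (0.68 log units; beyond the scatter), so only the move away from compound 2 stands clear of the scatter.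

Compound 4 `Cc1cc(C)cc(S(=O)(=O)c2c(C(=O)NC(C)c3ccccc3F)[nH]c3ccc(Cl)cc23)c1` is not yet measured. It differs from compound 3 by 2-fluorophenyl in place of ((pyrimidin-4-yl)methyl)carbamoyl on a saturated chain carbon bound to an amide-type nitrogen and a saturated chain carbon. Of the measured steps, a 1.3-fold higher number from compound 1 to compound 3 (0.11 log units; within the scatter) swapped only the terminal group on the amide-type nitrogen and left the number unchanged, whereas a 4.8-fold higher number from compound 2 to compound 3 (0.68 log units; beyond the scatter) rearranged the whole amide substituent and gave a modest rise. Going by the values given here, the present change is of the larger kind, so a step beyond the scatter in either direction is plausible, with no measured pair pointing to a direction. For compound 4 the expected step is a 1.9-fold lower number from compound 3 to compound 4 (0.27 log units; within the scatter), that is an estimated 15000 nM (range 5000 nM to 45000 nM).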

Compound 4, half-maximal cytotoxic concentration: > 51500 nM
Compound 4 ended at the assay's limit; the forecaster's own chance of this, stated with the estimate: 15%; middle value at least 3.4-fold (0.53 log units) away from the limit.
By their numbers in this assay, from the lowest: compound 2; then compounds 1 and 3 (each within the scatter of the next). At a limit, above all of these: compound 4.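

In this assay compound 4 stands at a limit of the assay, not at a number: the limit of > 51500 nM in this assay, at which 1 of the 4 values shown sits.
With 2-fluorophenyl on this saturated chain carbon there is an at least 1.8-fold higher number from compound 3 to compound 4 (0.26 log units; that floor lies within the scatter), so that floor does not separate the pair. Against the other two there is an at least 2.3-fold higher number from compound 1 to compound 4 (0.37 log units; beyond the scatter) and an at least 8.7-fold higher number from compound 2 to compound 4 (0.94 log units; beyond the scatter), both clear of the scatter.
So the amide arm with its terminal nitrogen ring is not needed here for a high number.

Open, as far as these compounds go, is how far compound 4 lies past its limit. Also open, from the compounds shown here alone, is whether unsubstituted phenyl, an amine or a carboxylic acid at this place would keep the number.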